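A Chalcone Rebuilt and Chlorine on a Shared Core

A few compounds are considered here, and "the series" means these few. Any claim that something is new, unique, unknown or untested is made for them only; others in the source may bear on it.

Compound 1 `COc1ccc(-c2cc(C(=O)/C=C/c3ccc(C)cc3)nc3cc(-c4ccccc4)nn23)cc1OC` is measured in a functional assay on DU-145 cells (Homo sapiens) for antiproliferative activity, read by MTT assay, with a stated time of 24 h (on this read-out lower numbers stand for stronger inhibition and higher numbers for weaker inhibition), at 19500 nM. Two close relatives have been measured the same way. Compound 2 `COc1ccc(-c2cc(C(=O)/C=C/c3cc(OC)c(OC)c(OC)c3)nc3cc(-c4ccccc4)nn23)cc1OC` gives 14700 nM, and compound 3 `COc1cc(-c2cc(C(=O)/C=C/c3ccc(C)cc3)nc3cc(-c4ccccc4)nn23)cc(OC)c1OC` gives 21900 nM. Compound 1 thus stands second highest of the three numbers, yet all three lie within the usual scatter of one another, so none can be called stronger or weaker than the rest. The two measured steps say the same: a 1.3-fold lower number from compound 1 to compound 2 (0.12 log units; within the scatter), and a 1.1-fold higher number from compound 1 to compound 3 (0.05 log units; within the scatter).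

Compound 4 `COc1ccc(-c2cc(/C=C/C(=O)c3ccc(Cl)cc3)nc3cc(-c4ccccc4)nn23)cc1OC` differs from compound 1 in one place: 2-((4-chlorophenyl)carbonyl)ethenyl in place of (2-(4-methylphenyl)ethenyl)carbonyl on an aromatic carbon. Here the order of carbonyl and double bond along the chain changes, and a chlorine replaces the methyl. Neither measured step touches the molecule in this way; the step to compound 2 alters only the outer ring, and the step to compound 3 alters only the other aromatic ring, and both stayed within the scatter. With no step beyond the scatter anywhere among these compounds, no change beyond the scatter is expected here either. Compound 4 is therefore expected at about 18000 nM, with a range from 6000 nM to 50000 nM, meaning an estimated step of a 1.1-fold lower number from compound 1 to compound 4 (0.03 log units; within the scatter).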

Compound 4, half-maximal inhibitory concentration: 21300 nM
Compound 4: middle estimate off by 1.2-fold (0.07 log units), on the low side; the measured number falls inside the stated range.
By their numbers in this assay, from the lowest: compounds 2, 1, 4 and 3 (each within the scatter of the next).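

In this assay, moving the carbonyl to the other end of the double bond and putting chlorine where the methyl stood gives a 1.1-fold higher number from compound 1 to compound 4 (0.04 log units; within the scatter), so compound 1 and compound 4 cannot be told apart. The earlier steps shown here altered only substituents on the outer ring or on the other aromatic ring, whereas this one rebuilds the chain on the aromatic carbon of the shared core, and even this larger rearrangement, which keeps the count of 11 heavy atoms, stays within the scatter. Nothing available explains this outcome.

The two edits arrive together in compound 4, so the effect of reversing the chain cannot be separated from that of exchanging methyl for chlorine, and they could be small on their own or could offset each other. Going by these compounds, it also remains open whether a different kind of group on this aromatic carbon, such as a carboxylic acid or an amine in place of the whole chain, would move the number beyond the scatter.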